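This account rests on a few compounds, and the source may have more. Where it says the series, first, only, none or still open, it means among the compounds named here.

In an assay on IMR-32 cells for displacement of a labelled ligand from corticotropin-releasing factor receptor 1 (Homo sapiens), read by scintillation counting, with a stated time of 2 h (a higher number here means a weaker inhibitor, a lower number a stronger inhibitor), compound 2 `CCc1nc(-c2ccc(C)cc2OC)c(CC)nc1NC(CC)CC` gives 23.7 nM, the highest of the three numbers recorded. Compound 1 `CCC(CC)Nc1nc(OC)c(-c2ccc(Cl)cc2Cl)nc1C` gives 14.4 nM in this assay, a number that lies within the scatter of that of compound 2. Compound 3 `CCc1nc(-c2cnc(C)cc2N(C)C)c(CC)nc1NC(CC)CC` gives 7.6 nM in this assay, and the gap between compound 2 and compound 3 is beyond the scatter, so compound 3 is the stronger of those two. Compound 4 `CCc1nc(-c2ccc(C(F)(F)F)cc2OC)c(CC)nc1NC(CC)CC` has not yet been measured. It differs from compound 2 in one place: trifluoromethyl in place of methyl on an aromatic carbon. Among the measured compounds shown here, no step between two measured compounds shows what such a change does to this assay, so the direction cannot be read from the numbers at hand. It is expected that compound 4 will give 15 nM in this assay, within the range 5 nM to 50 nM. This estimate means a step of a 1.6-fold lower number from compound 2 to compound 4 (0.20 log units; within the scatter) that is expected to be small, at most around the edge of the scatter.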

Compound 4, inhibition constant: 5.6 nM
Estimate against measurement, compound 4: 2.7-fold (0.43 log units) above; measured number inside the range.
By their numbers in this assay, from the lowest: compounds 4, 3, 1 and 2 (each within the scatter of the next, the first and the last beyond it).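

Among the compounds shown here, the pair gives the first reading of a change at this position: on the aromatic carbon para to a large group and meta to a methoxy group, trifluoromethyl in place of methyl goes with a 4.2-fold lower number from compound 2 to compound 4 (0.63 log units; beyond the scatter) in this assay. The earlier compounds shown here differ from one another in more than one place and could not isolate this carbon. Here, the entering group of 4 heavy atoms, against 1 for methyl, is accompanied by stronger inhibition rather than a loss, but no measurement at hand bears on the reason for this step.

A single step cannot show how other groups on this carbon would compare, such as a nitrile, an ethyl chain or an amine. It also leaves open whether trifluoromethyl in place of methyl would give a similar step with the methoxy group replaced.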